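A Carboxymethyl Group Becomes a Pyrrolidinyl Amide

The source may report more compounds than this note shows. Statements on the series, on what has been measured and on what is new or still open speak of the compounds shown alone.

Measured in an in vivo functional assay on the whole organism for inhibition, with Rattus norvegicus as the target; on this read-out lower numbers stand for an effect already at smaller amounts and higher numbers for an effect only at larger amounts of compound:

- Compound 1 `CCCCc1nc(CCC)c(CCC(=O)OCC)c(=O)n1Cc1ccc(-c2ccccc2-c2nnn[nH]2)cc1`: "not determined" (no result reported)
- Compound 2 `CCCCc1nc(C)c(CC(=O)O)c(=O)n1Cc1ccc(-c2ccccc2-c2nnn[nH]2)cc1`: 0.13 mg/kg
- Compound 3 `CCCc1nc(C)c(CC(=O)O)c(=O)n1Cc1ccc(-c2ccccc2-c2nnn[nH]2)cc1`: "not determined" (no result reported)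

Of these three compounds, only compound 2 carries a number, at 0.13 mg/kg. Among the compounds with values here, neither compound 1 nor compound 3 has a result, so compound 2 cannot be ranked against any neighbour, and the series offers no measured step to serve as a guide.

The next compound to be tested is compound 4 `CCCCc1nc(C)c(CC(=O)N2CCCC2)c(=O)n1Cc1ccc(-c2ccccc2-c2nnn[nH]2)cc1`. It keeps the structure of compound 2 except at one place, with pyrrolidin-1-yl in place of hydroxy on a carbonyl carbon. The same change can be read as carboxy to (pyrrolidin-1-yl)carbonyl.

Within the data shown here, the data contain no example of this change, so the expectation is a cautious one and rests on compound 2 at 0.13 mg/kg and the structural change alone. A moderate shift toward higher doses in this assay is expected, although a result within the usual scatter of compound 2 would not be surprising. The expected size of the change is a 3.8-fold higher number from compound 2 to compound 4 (0.59 log units; beyond the scatter). For compound 4 the estimated value is 0.5 mg/kg, with an expected range from 0.1 mg/kg to 3 mg/kg.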

Compound 4, dose for half-maximal effect: 0.056 mg/kg
Compound 4: the middle estimate sits 8.9-fold (0.95 log units) above what was measured, and the stated range ends above it.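

In this assay, a free carboxy group turns out not to be needed at this place, since replacing hydroxy with pyrrolidin-1-yl on the carbonyl carbon gives a 2.3-fold lower number from compound 2 to compound 4 (0.37 log units; beyond the scatter). Within the data shown here, this is the first measured step, and it shows that the carbonyl carbon of the carboxymethyl group can carry a substituent of five heavy atoms with a five-membered non-aromatic ring in place of a single oxygen, and that the effect is still reached at a lower dose. The change turns the carboxy group into a (pyrrolidin-1-yl)carbonyl group, but nothing available here explains why the number falls.

The step does not separate the contribution of the pyrrolidine ring from that of the amide as such, and a dimethylamino, piperidin-1-yl or morpholin-4-yl group on the same carbonyl carbon would be needed to tell these apart. As far as these compounds go, it also remains open whether the same exchange would give a step of similar direction and size on a shared core with another chain, such as a pentyl chain in place of butyl.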